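Reversing the sulfonamide linker of a potent receptor agonist

The source may report more compounds than this note shows. Statements on the series, on what has been measured and on what is new or still open speak of the compounds shown alone.

Compound 1 `Cc1cc2c(c(Oc3cccc(NS(=O)(=O)c4ccc(Cl)cc4)c3)n1)C(=O)N(C(C)C)C2=O` is the stronger of the two measured compounds: in a functional assay on HEK293 cells for agonist activity at Glucose-dependent insulinotropic receptor (Homo sapiens), read by cAMP accumulation, with a stated time of 30 min (a lower number here means that less compound is needed, a higher number that more compound is needed for the effect), compound 1 gives 13 nM, the lowest of the two numbers. Compound 2 `Cc1cc2c(c(Oc3cccc(NS(=O)(=O)c4ccc(Cl)cc4)c3)n1)C(=O)N(c1ccccc1)C2=O` gives 299 nM, and the step from compound 1 to compound 2 is a 23-fold higher number from compound 1 to compound 2 (1.36 log units; beyond the scatter), a large loss that comes from phenyl in place of isopropyl on the ring nitrogen.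

Compound 3 `Cc1cc2c(c(Oc3cccc(S(=O)(=O)Nc4ccc(Cl)cc4)c3)n1)C(=O)N(C(C)C)C2=O` keeps that isopropyl and instead turns the sulfonamide around: (4-chlorophenyl)sulfamoyl in place of ((4-chlorophenyl)sulfonyl)amino on an aromatic carbon. Among the compounds with values here, the only measured step concerns a different part of the molecule, so no measured step bears directly on this change, and the expectation rests on the two ends of the linker merely exchanging places while all atoms stay. A small weakening, a 2.3-fold higher number from compound 1 to compound 3 (0.36 log units; beyond the scatter), is expected. Compound 3 is estimated at 30 nM in this assay, with a range from 8 nM to 120 nM.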

Compound 3, half-maximal effective concentration: 238 nM
Beside the measured number, compound 3's estimate is 7.9-fold (0.90 log units) below it; measured number outside the range, above it.
By their numbers in this assay, from the lowest: compound 1; then compounds 3 and 2 (each within the scatter of the next).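

Reversing the sulfonamide is not a neutral swap at this position: in this assay, the change gives an 18-fold higher number from compound 1 to compound 3 (1.26 log units; beyond the scatter). The group that leaves and the group that enters hold the same atoms and the same counts of hydrogen-bond donors and acceptors, so these counts alone do not separate them, and the order of the atoms in the linker is what differs. Nothing available here explains why this reordering has so large an effect.

Going by these compounds, it remains open whether a carboxamide linker on the same aromatic carbon, or a methyl group on the sulfonamide nitrogen, would stay close to compound 1 or lose as much as compound 3. Also open, on these data alone, is how a phenyl group on the ring nitrogen would behave with the reversed linker.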